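This account rests on a few compounds, and the source may have more. Where it says the series, first, only, none or still open, it means among the compounds named here.

Three related compounds have been measured in an assay on isolated protein for inhibition of Dihydrofolate reductase (Mus musculus); on this read-out higher numbers stand for higher potency (the scale is a negative logarithm) and lower numbers for lower potency. Compound 1 `CC1(C)N=C(N)N=C(N)N1c1ccc(CCC(=O)Nc2ccc(S(=O)(=O)F)cc2)c(Cl)c1` gives 7.62 in this assay. Compound 2 `CC1(C)N=C(N)N=C(N)N1c1ccc(OCc2ccccc2S(=O)(=O)F)c(Cl)c1` gives 7.43, and compound 3 `CC1(C)N=C(N)N=C(N)N1c1ccc(OCc2ccc(Cl)cc2S(=O)(=O)F)c(Cl)c1` gives 7.52. All three numbers lie within the scatter of one another, so none of them can be set apart from the rest.

Compound 3 and compound 2 differ in one place: hydrogen in place of chloro on an aromatic carbon. This gave a number 0.09 log units lower from compound 3 to compound 2 (within the scatter). How the core of compound 1 differs from the core of compound 3 is not broken down here.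

Compound 4 `CC1(C)N=C(N)N=C(N)N1c1ccc(CCC(=O)Nc2ccc(S(=O)(=O)F)cc2)cc1` has not yet been measured. It arises from compound 1 by hydrogen in place of chloro on an aromatic carbon. Within the data shown here, this is the same kind of change as the one from compound 3 to compound 2, but not the same: there the site was meta to a fluorosulfonyl group and para to a large group, whereas here it is ortho to a large group and meta to a large group, on a different ring of the molecule.

Among the measured compounds shown here, the only guide is the earlier step, a number 0.09 log units lower from compound 3 to compound 2 (within the scatter), which sat within the scatter. The surroundings of the changed carbon differ from those of the earlier step. The step from compound 1 to compound 4 is expected to be a number 0.52 log units lower from compound 1 to compound 4 (beyond the scatter), with more uncertainty than the earlier one. Compound 4 is therefore estimated at 7.1, expected to fall between 6.5 and 7.6.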

Compound 4, logarithm of the reciprocal of the active concentration, log(1/C): 7.6
Compound 4: the middle estimate sits 0.50 log units below what was measured; measured number inside the range.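

Replacing the chloro group with hydrogen on the aromatic carbon of compound 1 in this assay gave a number 0.02 log units lower from compound 1 to compound 4 (within the scatter), so compound 4 cannot be told apart from its chlorinated partner. Set beside the earlier step, the change looks the same on both cores: the same change on two cores in this assay, a number 0.09 log units lower (within the scatter) from compound 3 to compound 2 and a number 0.02 log units lower (within the scatter) from compound 1 to compound 4, 0.07 log units apart, within the scatter of two such steps. This shows only that, at these two sites, swapping chloro for hydrogen left no readable mark on the number; the two sites lie on different rings and in different surroundings, so it does not show that the same swap would be as small at any other site or on any other core, and neither step says what the chloro group does there.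

The compounds shown leave open whether another group on that aromatic carbon, such as a methyl, a methoxy or a nitrile, would also leave the number within the scatter. They also leave open how the number would respond if a carboxylic acid or an amine took the place of the fluorosulfonyl group, or if compound 4 carried a longer chain on its amide.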